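This account rests on a few compounds, and the source may have more. Where it says the series, first, only, none or still open, it means among the compounds named here.

Working notes on the series. Compound 1 `COc1cc(-c2cc(/C=C/C(=O)c3ccc(Cl)c(Cl)c3)[nH]n2)cc(OC)c1OC` is the reference here: in a functional assay on RXF 393 cells (Homo sapiens) for cytotoxicity, read by sulforhodamine B assay, with a stated time of 48 h, tested at 0.1 uM (a higher number here means a weaker effect of the compound at the concentration tested, a lower number a stronger effect), compound 1 gives 96%, and the other two measured compounds sit together with it inside the usual scatter, compound 1 at the upper end of readings that do not separate. Compound 2 `COc1ccc(-c2cc(/C=C/C(=O)c3ccc(N)cc3)[nH]n2)cc1OC` gives 92% in this assay, and compound 3 `COc1ccc(-c2cc(/C=C/C(=O)c3ccc(N)cc3)[nH]n2)cc1` gives 88%. For the measured compounds named here, the one measured step, a number 4 percentage points lower from compound 2 to compound 3 (within the scatter), concerns hydrogen in place of methoxy on an aromatic carbon on the side of the core that carries the pyrazole aryl group, and it stays within the scatter.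

Compound 4 `COc1ccc(C(=O)/C=C/c2cc(-c3cc(OC)c(OC)c(OC)c3)n[nH]2)cc1OC` differs from compound 1 by 3,4-dimethoxyphenyl in place of 3,4-dichlorophenyl on a carbonyl carbon. Going by the values given here, no measured step concerns a change on the carbonyl carbon, so the expectation rests only on the narrow spread of the three readings and on the measured step staying within the scatter. For this assay, the expected step is a number 4 percentage points lower from compound 1 to compound 4 (within the scatter), not beyond the scatter. Compound 4 is estimated at 92%, with a range from 80% to 100%.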

Compound 4, a percentage reported as activity, at one concentration (the size of the read-out at that concentration, not a potency): 100%
The estimate for compound 4 lay 8 percentage points below the measured number, within the range that was stated.
By their numbers in this assay, from the lowest: compounds 3, 2, 1 and 4 (each within the scatter of the next, the first and the last beyond it).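

In this assay, for the compounds shown here, the change to a carbonyl carbon whose other neighbour is a double-bonded chain carbon gives a number 4 percentage points higher from compound 1 to compound 4 (within the scatter) and so provides the first measured step at this position, one that does not separate the two compounds. At the single concentration tested, 3,4-dimethoxyphenyl and 3,4-dichlorophenyl therefore give readings that cannot be told apart, although one carries methoxy groups and the other chlorine. Nothing available bears on why these two groups read alike.

As far as these compounds go, whether a different kind of group on the carbonyl carbon, such as a pyridine ring or a phenyl ring bearing a carboxylic acid, would give a reading beyond the scatter remains open. Also open, from the compounds shown here alone, is whether compound 1 and compound 4 would separate at other concentrations.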